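A few compounds are considered here, and "the series" means these few. Any claim that something is new, unique, unknown or untested is made for them only; others in the source may bear on it.

Measured compounds:
- compound 1, `C/C(=N\OCC(=O)O)c1ccc(Cl)s1`: 34 mg/kg
- compound 2, `C/C(=N\OCCCCCC(=O)O)c1ccc(Cl)cc1`: 92 mg/kg

Both compounds were tested in a functional assay on the whole organism for inhibition, with Rattus norvegicus as the target, read by paw edema, with stated times of 1 h and 3 h; on this read-out lower numbers stand for an effect already at smaller amounts and higher numbers for an effect only at larger amounts of compound. In this assay compound 2 gives 92 mg/kg, the highest of the two numbers. Compound 1 gives 34 mg/kg, a lower number, and the gap between the two lies beyond the usual scatter of such measurements. Going by the values given here, no pair of measured compounds differs in a single place, so no measured step shows what a single change does.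

Compound 3 `COC(=O)OCCO/N=C(\C)c1ccc(Cl)cc1` has not yet been measured. It differs from compound 2 in one place: (methoxycarbonyl)oxy in place of 3-carboxypropyl on a saturated chain carbon, two bonds along the chain from an oxygen. Among the compounds with values here, the acid group that both measured compounds carry is thus gone from compound 3, and no measured compound shows what happens without it. For this reason the expectation rests only on the fact that the two measured compounds, both acids, gave numbers in the tens. The step expected a 1.7-fold higher number from compound 2 to compound 3 (0.24 log units; within the scatter) is a moderate rise, meaning an effect only at larger amounts, but it is uncertain and could fall within the scatter. Compound 3 is estimated to give 160 mg/kg, with a range from 50 mg/kg to 500 mg/kg.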

Compound 3, dose for half-maximal effect: 33 mg/kg
Compound 3: middle estimate off by 4.8-fold (0.69 log units), on the high side, and the stated range ends above it.
By their numbers in this assay, from the lowest: compounds 3 and 1 (each within the scatter of the next); then compound 2.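

In this assay, putting (methoxycarbonyl)oxy in place of 3-carboxypropyl on a saturated chain carbon, two bonds along the chain from an oxygen, gives a 2.8-fold lower number from compound 2 to compound 3 (0.45 log units; beyond the scatter), a modest step towards an effect at smaller amounts. Going by these compounds alone, this is the first sign that this position of the chain does not need to end in a carboxylic acid for the compound to act in the whole animal, since the entering group has 0 hydrogen-bond donors and 3 hydrogen-bond acceptors, where the leaving group has 1 of each. Nothing shown here gives a reason for this step.

The swap also changes the group from 6 heavy atoms to 5 and replaces its carbon and oxygen make-up, so a single step cannot tell which of these differences matters. A methyl ester or a primary amide at the end of the same chain, or a hydroxyl group in the place of (methoxycarbonyl)oxy, would show whether the gain belongs to this particular group or appears with other ends that lack the carboxylic acid.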